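A few compounds are considered here, and "the series" means these few. Any claim that something is new, unique, unknown or untested is made for them only; others in the source may bear on it.

Measured so far in a functional assay on OVCAR-8 cells (Homo sapiens); a lower number here means a stronger inhibitor of growth, a higher number a weaker inhibitor of growth:
- compound 1 `O=S(=O)(/C=C/c1ccc(Cl)cc1Cl)Cc1ccc(Nc2ncnc3ccc(Br)cc23)cc1`: 3000 nM
- compound 2 `O=S(=O)(/C=C/c1ccc(C(F)(F)F)cc1F)Cc1ccc(Nc2ncnc3ccc(Br)cc23)cc1`: 15000 nM

Compound 2 at 15000 nM holds the higher of the two numbers, which makes it the weaker growth inhibitor of the pair.

Compound 3 `O=S(=O)(/C=C/c1ccc(F)cc1F)Cc1ccc(Nc2ncnc3ccc(Br)cc23)cc1` differs from compound 2 as follows: fluoro in place of trifluoromethyl on an aromatic carbon. This is fluoro in place of trifluoromethyl on an aromatic carbon, turning 2-fluoro-4-(trifluoromethyl)phenyl into 2,4-difluorophenyl.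

Among the measured compounds shown here, only one measured step bears on this change: a 5.0-fold higher number from compound 1 to compound 2 (0.70 log units; beyond the scatter). It brought in the 2-fluoro-4-(trifluoromethyl)phenyl group, but it is a different exchange, so the guidance is thin. Compound 1, at 3000 nM, also lacks trifluoromethyl. A modest step to a lower number in this assay is therefore expected, though a step within the scatter would not surprise.

The expected step is a 2.5-fold lower number from compound 2 to compound 3 (0.40 log units; beyond the scatter).

For compound 3 the estimated value is 6000 nM, with an expected range of 2000 nM to 18000 nM.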

Compound 3, concentration for 50% growth inhibition: 100000 nM
Compound 3: middle estimate off by 17-fold (1.22 log units), on the low side; the measured number lies above the stated range.
By their numbers in this assay, from the lowest: compound 1; then compound 2; then compound 3.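

In this assay, trifluoromethyl at this aromatic carbon, para to a large group, proves better than fluoro, with a 6.7-fold higher number from compound 2 to compound 3 (0.82 log units; beyond the scatter), so removing trifluoromethyl does not by itself move the series toward compound 1. The 2,4-difluorophenyl group also gives the largest step seen so far, a 33-fold higher number from compound 1 to compound 3 (1.52 log units; beyond the scatter), which places compound 3 as the weakest of the three and shows that growth inhibition here is highly sensitive to the substituents on this ring, with the shared core unchanged. Nothing available explains why fluoro at this carbon gives so much weaker a result.

Still open, on these data alone, is whether chloro on this same carbon, with the meta fluoro group kept, would bring the number back toward that of compound 1. As far as these compounds go, how a methoxy group, a nitrile or an amine would read at this carbon also remains unknown.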